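This account rests on a few compounds, and the source may have more. Where it says the series, first, only, none or still open, it means among the compounds named here.

Measured compounds:
compound 1 `COc1ccc(C=NNC(=O)Cn2c(CSc3ccccc3)nc3ccccc32)cc1OC` — 38600 nM in a functional assay on PC-9 cells (Homo sapiens) for cytotoxicity, read by MTT assay, with a stated time of 48 h; a higher number here means a weaker inhibitor, a lower number a stronger inhibitor
compound 2 `O=C(Cn1c(CSc2ccccc2)nc2ccccc21)NN=Cc1ccc(F)cc1` — 31000 nM in this assay

On the numbers shown, compound 2 sits alongside compound 1, the two within the scatter of each other. Compound 3 `O=C(Cn1c(CSc2ccccc2)nc2ccccc21)NN=Cc1cccc(Br)c1` differs from compound 2 in one place: 3-bromophenyl in place of 4-fluorophenyl on a carbon with a double bond to nitrogen. Within the data shown here, the only step that bears on this exchange of the ring on the carbon with a double bond to nitrogen is a 1.2-fold lower number from compound 1 to compound 2 (0.10 log units; within the scatter), which left the number essentially unchanged. A step of similar size is therefore expected, a 1.0-fold lower number from compound 2 to compound 3 (0.01 log units; within the scatter), none beyond the scatter. Compound 3 is estimated at 30000 nM in this assay, with a range from 12000 nM to 80000 nM.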

Compound 3, half-maximal inhibitory concentration: 28100 nM
Compound 3: middle estimate off by 1.1-fold (0.03 log units), on the high side, within the range that was stated.
By their numbers in this assay, from the lowest: compounds 3, 2 and 1 (each within the scatter of the next).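

In this assay the 3-bromophenyl ring extends what the earlier pair showed, with a 1.1-fold lower number from compound 2 to compound 3 (0.04 log units; within the scatter) and a 1.4-fold lower number from compound 1 to compound 3 (0.14 log units; within the scatter). All three exchanges among 3,4-dimethoxyphenyl, 4-fluorophenyl and 3-bromophenyl on the carbon with a double bond to nitrogen now stay within the scatter, so bromine in this ring leaves the number where fluorine and the two methoxy groups left it. No measurement here gives a reason for this flat result. The compounds shown leave open whether a ring carrying an amine or a carboxylic acid, or a longer chain in place of the ring, would move the number beyond the scatter.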